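Adding a carboxy group: from compound 1 to compound 4

The compounds below may be only part of what the source reports. "The series", "measured", "known", "first", "only" and "open" are said of these compounds alone.

Measured compounds:
compound 1, `Cn1c(-c2ccccc2)nc2c(NC3CCCC3)ncnc21`, 8510 nM
compound 2, `CCn1c(-c2ccccc2)nc2c(NC3CCC3)ncnc21`, 1440 nM
compound 3, `CCn1c(-c2ccccc2)nc2c(NC3CCCCC3)ncnc21`, 9020 nM

In a functional assay on CHO cells for antagonist activity at adenosine receptor A2b (Homo sapiens), read by 33P incorporation, with a stated time of 20 min (on this read-out higher numbers stand for weaker inhibition and lower numbers for stronger inhibition), compound 1 gives 8510 nM, the second highest of the three numbers. Its nearest neighbour is compound 3, whose number sits within the scatter of compound 1; compound 2 lies lower, beyond the scatter. Within the data shown here, the only single-site step among the measured compounds, a 6.3-fold higher number from compound 2 to compound 3 (0.80 log units; beyond the scatter), concerns the ring on the nitrogen and not the part of the molecule that changes here.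

Compound 4, `Cn1c(-c2ccc(C(=O)O)cc2)nc2c(NC3CCCC3)ncnc21`, differs from compound 1 in one place: carboxy in place of hydrogen on an aromatic carbon. Among the measured compounds shown here, no measured step touches this position, so the data give no direction for the change. The step is therefore expected to stay within the scatter, with a wide margin on either side: compound 4 is estimated at 5000 nM (range 1000 nM to 25000 nM), which means an expected 1.7-fold lower number from compound 1 to compound 4 (0.23 log units; within the scatter).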

Compound 4, inhibition constant: > 30000 nM
Compound 4: only a limit was reported; the forecaster's own chance of this, stated with the estimate: 5%; at least 6.0-fold (0.77 log units) between middle value and limit.
By their numbers in this assay, from the lowest: compound 2; then compounds 1 and 3 (each within the scatter of the next). At a limit, above all of these: compound 4.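

In this assay compound 4 is recorded only as a limit, > 30000 nM. The earlier compounds shown here said nothing about this aromatic carbon, para to a large group, but the position now proves sensitive to substitution: carboxy in place of hydrogen gives an at least 3.5-fold higher number from compound 1 to compound 4 (0.54 log units; beyond the scatter), a change towards weaker inhibition. How much weaker cannot be read, since the result is bounded on one side only: the limit of > 30000 nM in this assay, at which 1 of the 4 values shown sits.

The compounds shown leave open whether this shift belongs to the carboxylic acid itself or would also follow a methyl ester, a primary amide, an amine or a chlorine on the same carbon. They also leave open whether a smaller group such as methyl or hydroxy would be tolerated there.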